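The compounds below may be only part of what the source reports. "The series", "measured", "known", "first", "only" and "open" are said of these compounds alone.

Measured so far:
compound 1, `O=C(O)CCCCCOc1ccc2cc1COC/C=C/COCc1cccc(c1)-c1ccnc(n1)N2`: 45000 nM
compound 2, `O=C(O)c1cccc(NCCOc2ccc3cc2COC/C=C/COCc2cccc(c2)-c2ccnc(n2)N3)c1`: 53000 nM

In an assay on Sf9 cells for inhibition of protein deacetylase HDAC6 (Homo sapiens), read by fluorescence, with a stated time of 2 h (a lower number here means a stronger inhibitor, a higher number a weaker inhibitor), compound 2 gives 53000 nM, the highest of the two numbers; its nearest neighbour is compound 1 with 45000 nM, and the step of a 1.2-fold higher number from compound 1 to compound 2 (0.07 log units; within the scatter) lies within the scatter, so the two are not told apart. Compound 3, `O=C(NO)c1cccc(NCCOc2ccc3cc2COC/C=C/COCc2cccc(c2)-c2ccnc(n2)N3)c1`, differs from compound 2 in one place: hydroxyamino in place of hydroxy on a carbonyl carbon. Going by the values given here, the only measured step, that from compound 1 to compound 2, swaps one carboxylic acid bearer for another and leaves the carboxy itself untouched, so it does not bear on the exchange of the carboxy for a hydroxycarbamoyl, and no other measured pair covers it. The expectation therefore rests on the structural change alone, and a large step of an 880-fold lower number from compound 2 to compound 3 (2.95 log units; beyond the scatter) toward a lower number is expected in this assay. Compound 3 is estimated at 60 nM, with a wide range from 5 nM to 1500 nM.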

Compound 3, half-maximal inhibitory concentration: 2900 nM
Compound 3: middle estimate off by 48-fold (1.68 log units), on the low side; measured number above the stated range.
By their numbers in this assay, from the lowest: compound 3; then compounds 1 and 2 (each within the scatter of the next).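

In this assay the exchange of hydroxy for hydroxyamino on a carbonyl carbon gives an 18-fold lower number from compound 2 to compound 3 (1.26 log units; beyond the scatter) and so separates compounds in this series, which the change of the group carrying the carboxy between compound 1 and compound 2 did not do. The hydroxycarbamoyl compound also stands apart from the other carboxylic acid, with a 16-fold lower number from compound 1 to compound 3 (1.19 log units; beyond the scatter) over a change that covers the whole substituent on the chain. So, among these three compounds, the number follows what sits on the carbonyl carbon, while nothing at hand accounts for the size of the step.

As far as these compounds go, it remains open whether hydroxycarbamoyl on the hexanoic-type chain of compound 1 would give a similar step. From the compounds shown here alone, it is equally open how a primary amide or a thiol would read on the same carbonyl-bearing ring.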